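From chloro to bromo: the next compound

The source may hold more compounds than are shown below. What is called first, only, known or untested is meant among the compounds shown, and "the series" means these compounds.

Compound 1 `COc1ccc2[nH]cc(CCCN3CCN(C(=O)CN4CCN(C(=O)c5ccc(F)cc5)CC4)CC3)c2c1`: > 200000 nM
Compound 2 `COc1ccc2[nH]cc(CCCN3CCN(C(=O)CN4CCN(C(=O)c5cccc(Cl)c5)CC4)CC3)c2c1`: 143000 nM

Both compounds were tested in an ADME assay on HEK293 cells (Homo sapiens) for cytotoxicity, read by MTT assay, with a stated time of 72 h; on this read-out lower numbers stand for stronger inhibition and higher numbers for weaker inhibition. The result for compound 1 is a limit and not a number, as the limit of > 200000 nM in this assay, at which 1 of the 2 values shown sits, records. Among the compounds with values here, compound 2 therefore holds the only true number so far, 143000 nM.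

The next compound is compound 3 `COc1ccc2[nH]cc(CCCN3CCN(C(=O)CN4CCN(C(=O)c5cccc(Br)c5)CC4)CC3)c2c1`. It departs from compound 2 at a single place: bromo in place of chloro on an aromatic carbon. This puts bromo in place of chloro on an aromatic carbon, meta to a large group.

Within the data shown here, no measured step exchanges these two halogens. The nearest evidence is an at least 1.3-fold lower number from compound 1 to compound 2 (0.14 log units; that floor lies within the scatter), which concerns 3-chlorophenyl in place of 4-fluorophenyl on a carbonyl carbon, and its floor lies within the scatter. That step offers no support for a large change and points to no firm direction. In this assay, then, no step beyond the scatter is expected, and the estimate stays close to the number for compound 2. The expected change is a 1.0-fold lower number from compound 2 to compound 3 (0.01 log units; within the scatter). The estimated value for compound 3 is 140000 nM, with an expected range from 70000 nM to 220000 nM.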

Compound 3, half-maximal inhibitory concentration: 57000 nM
Beside the measured number, compound 3's estimate is 2.5-fold (0.39 log units) above it, outside the stated range (below it).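

Bromo in place of chloro on an aromatic carbon, meta to a large group, gives in this assay a 2.5-fold lower number from compound 2 to compound 3 (0.40 log units; beyond the scatter). This shows that exchanging one heavy atom at this place can move the read-out beyond the scatter, which the earlier step, with its floor inside the scatter, could not show. Set against 4-fluorophenyl on the carbonyl carbon, the 3-bromophenyl group gives an at least 3.5-fold lower number from compound 1 to compound 3 (0.54 log units; beyond the scatter), whereas the 3-chlorophenyl group gave only an at least 1.3-fold lower number from compound 1 to compound 2 (0.14 log units; that floor lies within the scatter), so only the bromo compound clears the scatter against that reference, and compound 1 is a limit and not a number, which makes both of these steps floors: the limit of > 200000 nM in this assay, at which 1 of the 3 values shown sits.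

As far as these compounds go, whether the number would keep falling with iodo at this place, or would respond in the same way to a methyl group, which is not a halogen, remains open. From the compounds shown here alone, it is also open whether the exchange of chloro for bromo would give a step of this size if a longer chain replaced the one that links the core to the rest of the molecule.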